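The compounds below may be only part of what the source reports. "The series", "measured", "known", "first", "only" and "open" are said of these compounds alone.

In a functional assay on HepG2 cells (Homo sapiens) for antiproliferative activity, read by MTT assay, with a stated time of 24 h (on this read-out higher numbers stand for weaker inhibition and lower numbers for stronger inhibition), compound 1 `COc1ccc(C(=O)/C=C/c2ccco2)c2c1C=CC(C)(C)O2` gives > 10000 nM, which is a limit of the assay and not a number. Compound 2 `COc1ccc(C(=O)/C=C/c2cccc(O)c2)c2c1C=CC(C)(C)O2` gives > 10000 nM in this assay, again a limit. Compound 3 `CCOc1cc(/C=C/C(=O)c2ccc(OC)c3c2OC(C)(C)C=C3)ccc1O` gives > 10000 nM in this assay, likewise a limit. Compound 3 thus has no numerical standing of its own and shares (the limit of > 10000 nM in this assay, at which 3 of the 3 values shown sit). Among the measured compounds shown here, the one measured step is a step that the two limits leave unreadable from compound 1 to compound 2, where a 3-hydroxyphenyl takes the place of a furan-2-yl, and it gives no size to carry forward. Compound 4 `COc1ccc(C(=O)/C=C/c2ccc(O)c(Br)c2)c2c1C=CC(C)(C)O2` has not yet been measured. It differs from compound 3 by bromo in place of ethoxy on an aromatic carbon, ortho to a hydroxy group and meta to a large group. For the measured compounds named here, no measured step touches that place, so the data support neither a gain nor a loss. The expectation therefore rests on compound 3, whose > 10000 nM is a limit. The expected change is a step that the limit leaves unreadable from compound 3 to compound 4, with no direction supported and no clear move beyond the scatter anticipated. For compound 4 the estimated value is 14000 nM, with an expected range from 5000 nM to 40000 nM.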

Compound 4, half-maximal inhibitory concentration: > 10000 nM
Compound 4 ended at the assay's limit (the forecaster's own chance of this, stated with the estimate: 70%); the middle value does not contradict the limit.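

The steps from compound 1, compound 2 and compound 3 to compound 4 cannot be read, since each of these compounds gives a limit of the assay and not a number: the limit of > 10000 nM in this assay, at which 4 of the 4 values shown sit.

The compounds shown leave open whether any of these changes, including bromo in place of ethoxy, shifts activity in this assay at all.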